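The source may hold more compounds than are shown below. What is called first, only, known or untested is meant among the compounds shown, and "the series" means these compounds.

Measured so far:
- compound 1, `CC(C)c1cc(C(C)(C)C)cc(-c2cccc(C(F)(F)F)c2)c1CO`: > 50000 nM in a functional assay on RKE cells for antagonist activity at Vasoactive intestinal polypeptide receptor 1 (Rattus norvegicus), read by HTRF and cAMP accumulation, with stated times of 10 min and 30 min; on this read-out higher numbers stand for weaker inhibition and lower numbers for stronger inhibition
- compound 2, `COc1ccc(-c2cc(C(C)(C)C)cc(C(C)C)c2CO)cc1`: 1300 nM
- compound 3, `CC(C)c1cc(C(C)(C)C)cc(-c2cccc(N(C)C)c2)c1CO`: 310 nM

Among the two numbers shown, compound 3 has the lowest, and compound 2 stands nearest to it. The value shown for compound 1 is a limit of this assay and not a number, as noted in the limit of > 50000 nM in this assay, at which 1 of the 3 values shown sits.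

Compound 4, `CC(C)c1cc(C(C)(C)C)cc(-c2cccc(-c3ccccc3)c2)c1CO`, differs from compound 3 in one place: phenyl in place of dimethylamino on an aromatic carbon.

Going by the values given here, only one measured step bears on this change. The step of an at least 160-fold lower number from compound 1 to compound 3 (2.20 log units; beyond the scatter) shows that bringing in the dimethylamino group went with a large drop in the number. Compound 4 takes that dimethylamino group away again and puts a phenyl in its place. Among the compounds with values here, since the only evidence points to the dimethylamino group as the source of the low number in compound 3, a rise in the number for compound 4 is expected, likely beyond the scatter, though how far is uncertain.

For compound 4 in this assay a value of 3000 nM is expected, with a range from 500 nM to 20000 nM, which would mean an estimated step of a 9.7-fold higher number from compound 3 to compound 4 (0.99 log units; beyond the scatter).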

Compound 4, half-maximal inhibitory concentration: 210 nM
For compound 4 the middle estimate is 14-fold (1.15 log units) above the measured one; the measured number lies below the stated range.
By their numbers in this assay, from the lowest: compounds 4 and 3 (each within the scatter of the next); then compound 2. At a limit, above all of these: compound 1.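

On this aromatic carbon, phenyl and dimethylamino read alike in this assay, with a 1.5-fold lower number from compound 3 to compound 4 (0.17 log units; within the scatter), so the low number of compound 3 does not depend on a nitrogen or a hydrogen-bond acceptor in this group, as phenyl has neither. Trifluoromethyl now stands apart from two quite different groups, as the change to phenyl gives an at least 230-fold lower number from compound 1 to compound 4 (2.37 log units; beyond the scatter). Compound 1 gives > 50000 nM, which is a limit of the assay and not a number.

Going by these compounds alone, what separates trifluoromethyl from the other two groups stays open, as only three groups are compared at this place. As far as these compounds go, whether a carboxylic acid, a primary amine or a longer chain such as n-butyl on this carbon would read like phenyl or like trifluoromethyl also remains unknown.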